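Rearranging the Same Atoms of Compound 2

The source may hold more compounds than are shown below. What is called first, only, known or untested is meant among the compounds shown, and "the series" means these compounds.

For the measured compounds named here, in a functional assay on MDA-MB-231 cells (Homo sapiens) for inhibition, read by MTT assay, with a stated time of 72 h (a higher number here means a weaker inhibitor, a lower number a stronger inhibitor), compound 2 `COc1ccccc1-c1csc2cnc(Nc3ccc(NC(=O)[C@H]4CCCNC4)cc3)nc12` gives 440 nM, the lowest of the three numbers so far. Compound 1 `COc1ccccc1-c1csc2cnc(Nc3ccc(NC(=O)C4CCNCC4)cc3)nc12` gives 1050 nM. The unmeasured compound 4 `COc1ccccc1-c1csc2cnc(Nc3ccc(C(=O)NC4CCNCC4)cc3)nc12` has the same atoms as compound 2, joined differently: (piperidin-4-yl)carbamoyl in place of ((piperidin-3-yl)carbonyl)amino on an aromatic carbon. In words, (piperidin-4-yl)carbamoyl stands in place of ((piperidin-3-yl)carbonyl)amino on an aromatic carbon.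

Going by the values given here, only one measured step compares two compounds directly: a 2.4-fold lower number from compound 1 to compound 2 (0.38 log units; beyond the scatter). This modest step came with piperidin-3-yl in place of piperidin-4-yl on a carbonyl carbon. Compound 4 gives up piperidin-3-yl, so that gain may be lost. Compound 3 `COc1ccccc1-c1csc2cnc(Nc3ccc(C(=O)NC4CCNCC4)cc3C)nc12` also carries (piperidin-4-yl)carbamoyl, along with an extra methyl, and it gives 3240 nM, the highest number here. Both observations suggest weaker inhibition, though neither compound is an exact match for this change.

The expected step is a 3.0-fold higher number from compound 2 to compound 4 (0.47 log units; beyond the scatter). For compound 4 the estimate is 1300 nM, with an expected range of 450 nM to 3500 nM.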

Compound 4, half-maximal inhibitory concentration: 110 nM
Compound 4: the middle estimate sits 12-fold (1.07 log units) above what was measured; the measured number lies below the stated range.
By their numbers in this assay, from the lowest: compound 4; then compound 2; then compound 1; then compound 3.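

With piperidin-4-yl held constant, reversing the amide link on the aromatic carbon alone gives a 9.5-fold lower number from compound 1 to compound 4 (0.98 log units; beyond the scatter), and the same reversed link also beats the piperidin-3-yl amide, with a 4.0-fold lower number from compound 2 to compound 4 (0.60 log units; beyond the scatter), so the ring position is not the only feature that matters here. Removing one methyl from an aromatic carbon gives a 29-fold lower number from compound 3 to compound 4 (1.47 log units; beyond the scatter), which shows that the high number seen earlier for the reversed amide went with that methyl and not with the reversed link itself. No measurement shown explains why any of these changes moves the number.

For the compounds shown here, still open is how piperidin-3-yl behaves on the reversed link, since its earlier gain was seen only on the original amide. Also open, going by these compounds, is whether an open-chain amine such as 2-aminoethyl could replace the piperidine ring on the carbamoyl nitrogen.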